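The source may report more compounds than this note shows. Statements on the series, on what has been measured and on what is new or still open speak of the compounds shown alone.

Measured compounds in an ADME assay on microsomes from liver (Homo sapiens) for metabolic stability, read by LC-MS, tested at 0.5 uM; on this read-out higher numbers stand for a longer-lived compound and lower numbers for a shorter-lived compound:
Compound 1 `COc1cccc(CCOc2ccc(-c3c(C)nc(C)c([C@H](OC(C)(C)C)C(=O)O)c3N3CCC(C)(C)CC3)cc2)c1` gives > 2 h, which is a limit of the assay.
Compound 2 `Cc1nc(C)c([C@H](OC(C)(C)C)C(=O)O)c(N2CCC(C)(C)CC2)c1-c1ccc(OCCc2ccc(F)c(F)c2)cc1` gives > 2 h, which is likewise a limit of the assay.
Compound 3 `Cc1nc(C)c([C@H](OC(C)(C)C)C(=O)O)c(N2CCC(C)(C)CC2)c1-c1ccc(OCCc2cccnc2)cc1` gives 0.367 h.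

Among the compounds with values here, compound 3 thus holds the only number in the set; the other two values sit at the limit of > 2 h in this assay, at which 2 of the 3 values shown sit. Compound 4 `Cc1nc(C)c(CCOc2ccc(-c3c(C)nc(C)c([C@H](OC(C)(C)C)C(=O)O)c3N3CCC(C)(C)CC3)cc2)s1` differs from compound 3 by 2,4-dimethyl-1,3-thiazol-5-yl in place of pyridin-3-yl on a saturated chain carbon, two bonds along the chain from an oxygen on an aromatic ring. Two measured steps end at compound 3 at this same place: an at least 5.4-fold lower number from compound 1 to compound 3 (0.73 log units; beyond the scatter) and an at least 5.4-fold lower number from compound 2 to compound 3 (0.73 log units; beyond the scatter). Within the data shown here, both arrive at pyridin-3-yl, one from 3-methoxyphenyl and one from 3,4-difluorophenyl, and neither leaves from pyridin-3-yl; no measured compound carries a 2,4-dimethyl-1,3-thiazol-5-yl. The remaining pair reads a step that the two limits leave unreadable from compound 1 to compound 2. On these data alone, the step to compound 4 therefore rests on no directly comparable measurement, and both a change within the scatter and a modest rise back toward the limit remain open. The expected step is a 1.6-fold higher number from compound 3 to compound 4 (0.21 log units; within the scatter). Compound 4 is estimated at 0.6 h in this assay, with a range from 0.2 h to 2 h.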

Compound 4, half-life: 0.917 h
For compound 4 the middle estimate is 1.5-fold (0.18 log units) below the measured one, and the stated range covers the measured number.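

At this place, on a saturated chain carbon two bonds along the chain from an oxygen on an aromatic ring, a change away from pyridin-3-yl now has a readable size in this assay: a 2.5-fold higher number from compound 3 to compound 4 (0.40 log units; beyond the scatter). The 2,4-dimethyl-1,3-thiazol-5-yl group still falls short of the two substituted phenyl groups, with an at least 2.1-fold lower number from compound 2 to compound 4 (0.33 log units; beyond the scatter) and an at least 2.1-fold lower number from compound 1 to compound 4 (0.33 log units; beyond the scatter), which places it between pyridin-3-yl and those groups in this set of compounds. Compound 1 and compound 2 both stand at a limit, and these two steps give only a minimum size: the limit of > 2 h in this assay, at which 2 of the 4 values shown sit.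

The step between compound 1 and compound 2 cannot be read. On these data alone, whether the gain belongs to the five-membered ring or to its methyl groups stays open, and an unsubstituted 1,3-thiazol-5-yl would separate the two.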